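Swapping the Aryl Group on a Saturated Ring Carbon

The source may report more compounds than this note shows. Statements on the series, on what has been measured and on what is new or still open speak of the compounds shown alone.

Of the compounds shown here, three have been tested in a functional assay on PC-3 cells (Homo sapiens) for antiproliferative activity, read by MTT assay, tested at 5 uM; a higher number here means a stronger effect of the compound at the concentration tested, a lower number a weaker effect. Compound 1 `COc1cc(C2=NN(C(C)=O)C(c3c(Cl)cccc3Cl)O2)cc(OC)c1OC` gives -2.2%, compound 2 `COc1cc(C(=O)N/N=C/c2cccc(F)c2)cc(OC)c1OC` gives 64.1%, and compound 3 `COc1ccc(C2OC(c3cc(OC)c(OC)c(OC)c3)=NN2C(C)=O)c(OC)c1` gives 92%. Compound 3 stands highest of the three numbers; its gap to compound 2 is beyond the scatter, and its gap to compound 1 is the largest of all, as shown by a number 94.2 percentage points higher from compound 1 to compound 3 (beyond the scatter).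

Compound 4 `COc1cc(C2=NN(C(C)=O)C(c3ccc(F)cc3)O2)cc(OC)c1OC` has not yet been measured. (4-fluorophenyl in place of 2,4-dimethoxyphenyl on a saturated ring carbon). Going by the values given here, only one measured step touches this place: a number 94.2 percentage points higher from compound 1 to compound 3 (beyond the scatter), a very large rise that shows how strongly the group on this saturated ring carbon can shift the read-out. That step, however, concerned 2,6-dichlorophenyl and 2,4-dimethoxyphenyl, not 4-fluorophenyl, and compound 2 sits on a different core, so it cannot serve as a step here. Since the group that made compound 3 strong leaves, a loss beyond the scatter seems more likely than a gain, but its size is open.

Compound 4 is therefore expected to give 45%, with a range from 5% to 85%. This corresponds to an expected downward step of a number 47 percentage points lower from compound 3 to compound 4 (beyond the scatter).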

Compound 4, a percentage reported as inhibition, at one concentration (the size of the read-out at that concentration, not a potency): 0.1%
Compound 4: middle estimate off by 44.9 percentage points, on the high side; the whole stated range lies above it.
By their numbers in this assay, from the lowest: compounds 1 and 4 (each within the scatter of the next); then compound 2; then compound 3.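

In this assay, the change from 2,4-dimethoxyphenyl to 4-fluorophenyl gives a number 91.9 percentage points lower from compound 3 to compound 4 (beyond the scatter) on the shared core, so the high number of compound 3 does not carry over to every aryl group at this saturated ring carbon. The swap from 2,6-dichlorophenyl to 4-fluorophenyl gives a number 2.3 percentage points higher from compound 1 to compound 4 (within the scatter), which means these two halogen-bearing aryl groups cannot be told apart here, and among these three compounds only the one with 2,4-dimethoxyphenyl stands apart. Nothing at hand explains why this group behaves differently from the other two.

The compounds shown leave open whether both methoxy groups are needed, since none of them has a phenyl group carrying just one methoxy group, and they cannot separate the loss of the methoxy groups from the arrival of the halogens. From the compounds shown here alone, it also remains open how a phenyl group carrying a hydroxyl group or an amine, or a longer alkoxy chain such as ethoxy in place of methoxy, would read out at this position.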